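Benzyl Ester of an Amino Acid Side Chain: Compound 4

A few compounds are considered here, and "the series" means these few. Any claim that something is new, unique, unknown or untested is made for them only; others in the source may bear on it.

Measured compounds:
compound 1 `CC(C)[C@H](NC(=O)CN(c1nc(Cl)nc2[nH]cnc12)C1CC1)C(=O)OCc1ccccc1` gives 33.4%
compound 2 `C[C@@H](O)[C@H](NC(=O)CN(c1nc(Cl)nc2[nH]cnc12)C1CC1)C(=O)OCc1ccccc1` gives 21.9%
compound 3 `NC(=O)C[C@H](NC(=O)CN(c1nc(Cl)nc2[nH]cnc12)C1CC1)C(=O)O` gives 29.7%

In a functional assay on the whole organism (Tail, strain ICR) with Mus musculus as the target, in the tail flick test, with a stated time of 30 min, at a dose of 25 umol/kg by the oral route (on this read-out lower numbers stand for a weaker effect and higher numbers for a stronger effect at the one dose given), compound 3 stands second of the three numbers. Its nearest neighbour is compound 1, whose value sits within the scatter of that of compound 3, and its furthest is compound 2, whose value also lies within the scatter. Compound 3 is the only one of the three that carries a free carboxy group; compound 1 and compound 2 both carry a benzyloxycarbonyl group.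

Compound 4 `NC(=O)C[C@H](NC(=O)CN(c1nc(Cl)nc2[nH]cnc12)C1CC1)C(=O)OCc1ccccc1` is not yet measured. It differs from compound 3 by benzyl in place of hydrogen on an oxygen next to a carbonyl group.

Within the data shown here, only one measured step exists, a number 11.5 percentage points lower from compound 1 to compound 2 (beyond the scatter), and it concerns a change on the saturated chain carbon, not the oxygen next to the carbonyl group. Among the measured compounds shown here, no measured step therefore bears directly on the change from compound 3 to compound 4. The two benzyl esters, compound 1 and compound 2, give values that bracket that of compound 3, both within the scatter of it. On that basis a step of a number 1.3 percentage points higher from compound 3 to compound 4 (within the scatter) is expected, no larger than the scatter. Compound 4 is estimated at 31%, between 16% and 46%.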

Compound 4, a percentage reported as activity, at one dose (the size of the read-out at that dose, not a potency): 24.4%
The estimate for compound 4 lay 6.6 percentage points above the measured number; the range from low to high includes it.
By their numbers in this assay, from the lowest: compounds 2, 4, 3 and 1 (each within the scatter of the next, the first and the last beyond it).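

In this assay, among these compounds, the change at this oxygen can now be read for the first time: benzyl in place of hydrogen on an oxygen next to a carbonyl group gives a number 5.3 percentage points lower from compound 3 to compound 4 (within the scatter), so with carbamoylmethyl on the chain carbon, the carboxy and benzyloxycarbonyl forms are not told apart at this single dose. The chain carbon also gains two readings among the benzyl esters, with carbamoylmethyl in place of 1-hydroxyethyl giving a number 2.5 percentage points higher from compound 2 to compound 4 (within the scatter) and carbamoylmethyl in place of isopropyl giving a number 9 percentage points lower from compound 1 to compound 4 (within the scatter), which places carbamoylmethyl within the scatter of both groups, even though those two groups themselves differ beyond it. Nothing available explains these numbers.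

The compounds shown pair a free carboxy group and a benzyloxycarbonyl group only with carbamoylmethyl on the chain carbon, so it stays open whether the same exchange would read alike with isopropyl or 1-hydroxyethyl there. Also open, going by these compounds, is how a methyl ester, an ethyl ester or a primary carboxamide in this place would read at this dose.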